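Swapping a hydrazide for a phenylpiperazine amide

The source may report more compounds than this note shows. Statements on the series, on what has been measured and on what is new or still open speak of the compounds shown alone.

Compound 1 `NNC(=O)c1c(NC(=O)NS(=O)(=O)c2ccccc2)sc2c1CCCCC2` is the strongest of the three measured compounds in a functional assay on cells (Cancer cell lines, Homo sapiens) for inhibition, with a stated time of 48 h (a lower number here means a stronger inhibitor of growth, a higher number a weaker inhibitor of growth), where compound 1 gives 1500 nM. Compound 2 `O=C(Nc1sc2c(c1C(=O)NNc1ccccc1)CCCCC2)NS(=O)(=O)c1ccccc1` gives 15200 nM in this assay, a weakening of a 10-fold higher number from compound 1 to compound 2 (1.01 log units; beyond the scatter) for the change of phenyl in place of hydrogen on an amine nitrogen. Compound 3 `CCCNC(=O)c1c(NC(=O)NS(=O)(=O)c2ccccc2)sc2c1CCCCC2` gives 76500 nM, a weakening of a 51-fold higher number from compound 1 to compound 3 (1.71 log units; beyond the scatter) for propyl in place of amino on an amide-type nitrogen.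

Compound 4 `O=C(Nc1sc2c(c1C(=O)N1CCN(c3ccccc3)CC1)CCCCC2)NS(=O)(=O)c1ccccc1` differs from compound 1 by 4-phenylpiperazin-1-yl in place of aminoamino on a carbonyl carbon. This removes the whole aminoamino end, including both of its hydrogen-bond donors. Both measured steps away from compound 1 point the same way: changing the amino end weakened growth inhibition, modestly in compound 2 and strongly in compound 3. Compound 4 goes further than either, so a large weakening is expected in this assay, with the step from compound 1 estimated at a 20-fold higher number from compound 1 to compound 4 (1.30 log units; beyond the scatter). Compound 4 is therefore estimated at 30000 nM, with a range from 8000 nM to 120000 nM.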

Compound 4, concentration for 50% growth inhibition: 36200 nM
The estimate for compound 4 lay 1.2-fold (0.08 log units) below the measured number; low and high end bracket the measured number.
By their numbers in this assay, from the lowest: compound 1; then compound 2; then compound 4; then compound 3.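

In this assay, the large step of a 24-fold higher number from compound 1 to compound 4 (1.38 log units; beyond the scatter) adds a third replacement at this carbonyl carbon that falls short of aminoamino, so every end shown here is weaker than the one in compound 1. The modest steps of a 2.1-fold lower number from compound 3 to compound 4 (0.32 log units; beyond the scatter) and a 2.4-fold higher number from compound 2 to compound 4 (0.38 log units; beyond the scatter) show that 4-phenylpiperazin-1-yl, despite having no hydrogen-bond donors, does not give the weakest compound, as compound 3 with its smaller propylamino end and retained amide hydrogen stands higher still. No measurement here explains these differences.

The compounds shown leave open how a plain piperazine without its phenyl ring, or a hydrazide carrying a single methyl group, would behave. Such groups would help separate the loss of the nitrogen hydrogens from the addition of the phenyl ring.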